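This account rests on a few compounds, and the source may have more. Where it says the series, first, only, none or still open, it means among the compounds named here.

Three compounds are in hand in a functional assay on DLD-1 cells (Homo sapiens) for antiproliferative activity, read by CellTiter-Glo, with a stated time of 72 h; a lower number here means a stronger inhibitor, a higher number a weaker inhibitor. Compound 1 `CC1CCN(C2CCN(S(=O)(=O)c3cccc(-c4ccccc4C(F)(F)F)c3)CC2)CC1` gives 10 nM, the lowest of the three numbers. Compound 3 `COc1ccccc1-c1ccc(S(=O)(=O)N2CCC(N3CCC(C)CC3)CC2)cc1` gives 26 nM in this assay, a step beyond the scatter above compound 1, and compound 2 `COc1ccc(S(=O)(=O)N2CCC(N3CCC(C)CC3)CC2)cc1OC` gives 138 nM in this assay, the number furthest from compound 1. Compound 4 `Cc1cc(C)cc(-c2cccc(S(=O)(=O)N3CCC(N4CCC(C)CC4)CC3)c2)c1` has not yet been measured. It differs from compound 1 in one place: 3,5-dimethylphenyl in place of 2-(trifluoromethyl)phenyl on an aromatic carbon. For the measured compounds named here, no measured pair isolates this change, so the direction of the step rests on compound 1 alone. The expected step is small, toward a higher number, and possibly within the scatter: a 1.8-fold higher number from compound 1 to compound 4 (0.26 log units; within the scatter). Compound 4 is estimated at 18 nM in this assay, within a range of 6 nM to 55 nM.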

Compound 4, half-maximal inhibitory concentration: 41 nM
The estimate for compound 4 lay 2.3-fold (0.36 log units) below the measured number; the measured number falls inside the stated range.
By their numbers in this assay, from the lowest: compound 1; then compounds 3 and 4 (each within the scatter of the next); then compound 2.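

For the compounds shown here, on this aromatic carbon, 3,5-dimethylphenyl in place of 2-(trifluoromethyl)phenyl gives a 4.1-fold higher number from compound 1 to compound 4 (0.61 log units; beyond the scatter) in this assay, the first pair to isolate a change at this position. The step is modest, so the position responds to the choice of aryl group, yet accepts both of these groups without a large loss. No data here account for the step.

Substituent identity and substituent placement change together in this pair, and the two remain unseparated. Also open, from the compounds shown here alone, is how an unsubstituted phenyl, a pyridine or an aryl group carrying an amine or a carboxylic acid would read at this carbon.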